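This account rests on a few compounds, and the source may have more. Where it says the series, first, only, none or still open, it means among the compounds named here.

Compound 1 `Cc1cc(C)c(-c2nc(CN3CCC(C(=O)NCCCN4C[C@H](C)C[C@H](C)C4)CC3)c(C)o2)c(C)c1` gives "not determined" (no result reported) in a physicochemical assay for permeability, using PAMPA (a higher number here means that the compound crosses the layer faster, a lower number that the compound crosses the layer more slowly), so there is no number for it to start from. Two close relatives set the range: compound 2 `Cc1cccc(F)c1-c1nc(CN2CCC(C(=O)NCCCN3C[C@H](C)C[C@H](C)C3)CC2)c(C)o1` gives 234 10^-6 cm/s, and compound 3 `CCc1ccccc1-c1nc(CN2CCC(C(=O)NCCCN3C[C@H](C)C[C@H](C)C3)CC2)c(C)o1` gives 106 10^-6 cm/s. The step of a 2.2-fold lower number from compound 2 to compound 3 (0.34 log units; beyond the scatter) came from exchanging only the substituted phenyl group on the shared core. Compound 4 `Cc1cc(C)cc(-c2nc(CN3CCC(C(=O)NCCCN4C[C@H](C)C[C@H](C)C4)CC3)c(C)o2)c1` differs from compound 1 by 3,5-dimethylphenyl in place of 2,4,6-trimethylphenyl on an aromatic carbon. For the measured compounds named here, this change also touches only that phenyl group, and the one measured step of this kind was modest, so a value close to those of compound 2 and compound 3 is expected, with no direction that the data can show. For compound 4 the estimate is 160 10^-6 cm/s, within 70 10^-6 cm/s to 350 10^-6 cm/s.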

Compound 4, apparent permeability: 864 10^-6 cm/s
Estimate against measurement, compound 4: 5.4-fold (0.73 log units) below, outside the stated range (above it).
By their numbers in this assay, from the lowest: compound 3; then compound 2; then compound 4.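

Exchanging only the phenyl group at this position gives an 8.2-fold higher number from compound 3 to compound 4 (0.91 log units; beyond the scatter) and a 3.7-fold higher number from compound 2 to compound 4 (0.57 log units; beyond the scatter). Compound 4, with its 3,5-dimethylphenyl group, therefore has the highest number of the three measured compounds in this assay, and both steps are wider than the one between the two earlier compounds. Nothing available explains this rise.

Where the 2,4,6-trimethylphenyl group of compound 1 falls among these values stays open. So does how a phenyl group carrying an amine or a carboxylic acid would read here.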